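This account rests on a few compounds, and the source may have more. Where it says the series, first, only, none or still open, it means among the compounds named here.

Measured compounds:
Compound 1 `CCC1=C(O)c2c(oc(-c3ccc(CC(C)C)cc3)cc2=O)C(CC)(CC)C1=O` in a functional assay on KB cells (Homo sapiens) for antiproliferative activity, read by sulforhodamine B assay, with a stated time of 3 days; on this read-out higher numbers stand for an effect only at larger amounts of compound and lower numbers for an effect already at smaller amounts: 29.3 uM
Compound 2 `CCC1=C(O)c2c(oc(-c3ccc(Br)cc3)cc2=O)C(CC)(CC)C1=O` in this assay: only a limit of the assay, > 48.1 uM

Compound 2 stands at the edge of what this assay can report: its value is a limit, not a number, and it is the weaker of the two values shown. Among the compounds with values here, the one measured step that bears on the change below is an at least 1.6-fold higher number from compound 1 to compound 2 (0.21 log units; that floor lies within the scatter), where bromo in place of isobutyl pushed the number up to the limit, as the limit of > 48.1 uM in this assay, at which 1 of the 2 values shown sits, records.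

Compound 3 `CCC1=C(O)c2c(oc(-c3ccc(C)c(F)c3)cc2=O)C(CC)(CC)C1=O` is reached from compound 2 by 3-fluoro-4-methylphenyl in place of 4-bromophenyl on an aromatic carbon. The entering 3-fluoro-4-methylphenyl carries a methyl, an alkyl group like the isobutyl of compound 1 though smaller, together with a fluorine, and the leaving bromo is removed. Given that the bromo step an at least 1.6-fold higher number from compound 1 to compound 2 (0.21 log units; that floor lies within the scatter) went toward the limit, removing it is expected to bring the number back down somewhat, yet because compound 2 sits at a limit of > 48.1 uM in this assay, at which 1 of the 2 values shown sits, the size of that return cannot be fixed. Compound 3 is therefore expected to show a step of an at least 1.3-fold lower number from compound 2 to compound 3 (0.13 log units; that floor lies within the scatter). Compound 3 is estimated at 35 uM, within 12 uM to 100 uM.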

Compound 3, concentration for half-maximal effect: 28.1 uM
Compound 3: the middle estimate sits 1.2-fold (0.10 log units) above what was measured, and the stated range covers the measured number.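

Compound 3 gives a real number in this assay, so this aromatic carbon can carry a 3-fluoro-4-methylphenyl and yield a reading inside the range of the assay, which the 4-bromophenyl of compound 2 did not do. The step is an at least 1.7-fold lower number from compound 2 to compound 3 (0.23 log units; that floor lies within the scatter), and since it is only a floor, lying within the usual scatter, the true size of this change stays unknown, as compound 2 has only a limit and not a number: the limit of > 48.1 uM in this assay, at which 1 of the 3 values shown sits.

Compound 1 gives 29.3 uM and compound 3 gives 28.1 uM, and these two values lie within the usual scatter of each other, so the isobutyl of compound 1 and the methyl and fluorine of compound 3 cannot be told apart in this assay.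

The methyl and the fluorine enter together, so the compounds shown do not say whether either one alone, as in a plain 4-methylphenyl or 3-fluorophenyl, would give a similar reading. They also leave open what a quite different group on that phenyl ring, such as an amine, a carboxylic acid or a longer alkyl chain, would do to the number.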